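A few compounds are considered here, and "the series" means these few. Any claim that something is new, unique, unknown or untested is made for them only; others in the source may bear on it.

Of the compounds shown here, three have been measured in a functional assay on A549 cells (Homo sapiens) for antiproliferative activity, read by MTT assay, with a stated time of 48 h; a higher number here means a weaker inhibitor, a lower number a stronger inhibitor.
Compound 1 `CCc1cccc(C)c1-n1nncc1CN1C(=O)C2(C(C#N)=C(N)Oc3c(N)cc4nc5ccccc5nc4c32)c2ccccc21` gives > 50000 nM, which is a limit of the assay.
Compound 2 `CCc1cccc(CC)c1-n1nncc1CN1C(=O)C2(C(C#N)=C(N)Oc3c(N)cc4nc5ccccc5nc4c32)c2ccccc21` gives > 50000 nM, which is a limit of the assay.
Compound 3 `N#CC1=C(N)Oc2c(N)cc3nc4ccccc4nc3c2C12C(=O)N(Cc1cnnn1-c1ccc(Cl)cc1Cl)c1ccccc12` gives > 50000 nM, which is a limit of the assay.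

Compound 3 therefore has no number of its own in this assay, only a limit, and the two other values are limits as well (the limit of > 50000 nM in this assay, at which 3 of the 3 values shown sit). For that reason the steps among these three compounds, a step that the two limits leave unreadable from compound 1 to compound 2, a step that the two limits leave unreadable from compound 1 to compound 3 and a step that the two limits leave unreadable from compound 2 to compound 3, cannot be read in size or direction.

Compound 4 `N#CC1=C(N)Oc2c(N)cc3nc4ccccc4nc3c2C12C(=O)N(Cc1cnnn1-c1ccc([N+](=O)[O-])cc1[N+](=O)[O-])c1ccccc12` differs from compound 3 in one place: 2,4-dinitrophenyl in place of 2,4-dichlorophenyl on an aromatic nitrogen. The two measured steps that also exchange the group on that aromatic nitrogen, a step that the two limits leave unreadable from compound 1 to compound 3 and a step that the two limits leave unreadable from compound 2 to compound 3, have no readable size, so they give no guide to how large a change in this assay to expect, or in which direction. All that can be said is that three different groups on that aromatic nitrogen left every compound at the limit. The expected step is a step that the limit leaves unreadable from compound 3 to compound 4, with a wide range around it. Compound 4 is estimated to give about 60000 nM in this assay, between 20000 nM and 200000 nM, and most likely to be reported again only as a limit.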

Compound 4, half-maximal inhibitory concentration: > 50000 nM
Compound 4 was reported as a limit; the forecaster's own chance of this, stated with the estimate: 80%; the middle value is on the limit's open side.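

No step among compound 1, compound 2, compound 3 and compound 4 can be read, in size or direction, because all four compounds stand at the same limit: the limit of > 50000 nM in this assay, at which 4 of the 4 values shown sit.

Left open is whether these different groups on the aromatic nitrogen differ at all in this assay, and what change would give a compound a measurable number there.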